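Piperazine substitution and microsomal stability in a fused pyridine series

This account rests on a few compounds, and the source may have more. Where it says the series, first, only, none or still open, it means among the compounds named here.

Compound 1 `c1cnc2c(c1)CCC[C@@H]2N(CC1CC1)C[C@H]1Cc2c(cccc2N2CCNCC2)CN1`: 82.1%
Compound 2 `C[C@@H]1CN(c2cccc3c2C[C@H](CN(C)[C@H]2CCCc4cccnc42)NC3)C[C@H](C)N1`: 100%
Compound 3 `CC(C)N1CCN(c2cccc3c2C[C@H](CN(C)[C@H]2CCCc4cccnc42)NC3)CC1`: 56.6%

In an ADME assay on microsomes from liver (Homo sapiens) for metabolic stability, read by LC-MS, with a stated time of 10 min (a lower number here means that less of the compound is left, a higher number that more of the compound is left), compound 2 gives 100%, the highest of the three numbers. Its nearest neighbour is compound 1, which gives 82.1% in this assay; compound 3, the furthest, gives 56.6%.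

Compound 4 `CN(C[C@H]1Cc2c(cccc2N2CCNCC2)CN1)[C@H]1CCCc2cccnc21` has not yet been measured in this assay. It differs from compound 2 in one place: piperazin-1-yl in place of 3,5-dimethylpiperazin-1-yl on an aromatic carbon.

Among the measured compounds shown here, only one measured step changes the same group on the same aromatic carbon: a number 43.4 percentage points lower from compound 2 to compound 3 (beyond the scatter). That step exchanged the 3,5-dimethylpiperazin-1-yl for a larger substituted piperazine, and the number fell well beyond the scatter. Compound 1 also carries a piperazin-1-yl on that carbon, though it differs from compound 4 elsewhere, and in this assay compound 1 gives 82.1%. Taken together, a fall of moderate size is expected for compound 4, because the same group in compound 1 went with 82.1% while the substituted variant in compound 3 went with 56.6%. The expected step is a number 16 percentage points lower from compound 2 to compound 4 (beyond the scatter). Compound 4 is therefore estimated at 84% in this assay, with a range from 65% to 100%.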

Compound 4, percent of the compound remaining: 99.7%
Compound 4: the middle estimate sits 15.7 percentage points below what was measured, and the stated range covers the measured number.
By their numbers in this assay, from the lowest: compound 3; then compound 1; then compounds 4 and 2 (each within the scatter of the next).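

In this assay, the two methyl groups of 3,5-dimethylpiperazin-1-yl prove unnecessary for a high number on this aromatic carbon: with piperazin-1-yl in its place, the result is a number 0.3 percentage points lower from compound 2 to compound 4 (within the scatter), so the two groups cannot be told apart here. The low number of compound 3 now attaches to the isopropyl on the amine nitrogen in the ring, as hydrogen in place of that isopropyl gives a number 43.1 percentage points higher from compound 3 to compound 4 (beyond the scatter). Piperazin-1-yl alone does not settle the number either: with hydrogen in place of cyclopropyl on the saturated chain carbon bound to an amine nitrogen, the result is a number 17.6 percentage points higher from compound 1 to compound 4 (beyond the scatter), which shows that a change away from this aromatic carbon also moves the read-out.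

No evidence here accounts for any of these steps. The compounds shown leave open whether a methyl or an acetyl on the amine nitrogen in the ring would keep the number of compound 4 or move it towards that of compound 3, and whether a morpholine on the same aromatic carbon would keep it.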